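The compounds below may be only part of what the source reports. "The series", "measured", "known", "first", "only" and "open" are said of these compounds alone.

Measured in a functional assay on A549 cells (Homo sapiens) for cytotoxicity, read by MTT assay, with a stated time of 72 h; a higher number here means a weaker inhibitor, a lower number a stronger inhibitor:
- compound 1 `COc1cccc(/C=C2\CCC/C(=C\c3ccc(Cl)cc3)C2=O)c1OC`: > 20000 nM, a limit of the assay
- compound 2 `COc1cccc(/C=C2\CCC/C(=C\c3ccc(Br)cc3)C2=O)c1OC`: > 20000 nM, a limit of the assay
- compound 3 `COc1cccc(/C=C2\CCC/C(=C\c3cccc(OC)c3OC)C2=O)c1`: 16400 nM

Among the compounds with values here, compound 3 has the only actual number in the set. The other two compounds stand at the limit of > 20000 nM in this assay, at which 2 of the 3 values shown sit.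

Compound 4 `COc1ccc(/C=C2\CCC/C(=C\c3cccc(OC)c3OC)C2=O)cc1` has the same atoms as compound 3, joined differently: 4-methoxyphenyl in place of 3-methoxyphenyl on a double-bonded chain carbon bound to a double-bonded ring carbon. In words, it has 4-methoxyphenyl in place of 3-methoxyphenyl on a double-bonded chain carbon bound to a double-bonded ring carbon.

Two measured steps change the group at this place: an at least 1.2-fold lower number from compound 1 to compound 3 (0.08 log units; that floor lies within the scatter) and an at least 1.2-fold lower number from compound 2 to compound 3 (0.08 log units; that floor lies within the scatter). Both are only floors, so neither gives a full size, and neither involves the 4-methoxyphenyl group. With so little to go on, no shift beyond the scatter is expected in this assay, in either direction. The estimated step is a 1.1-fold higher number from compound 3 to compound 4 (0.04 log units; within the scatter). A reading at the limit of the assay remains quite possible. For compound 4 the expected value is 18000 nM, with an estimated range of 9000 nM to 36000 nM.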

Compound 4, half-maximal inhibitory concentration: > 20000 nM
Compound 4 ended at the assay's limit; the forecaster's own chance of this, stated with the estimate: 45%; middle value at least 1.1-fold (0.04 log units) from the limit.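

In this assay, within the data shown here, 4-methoxyphenyl in place of 3-methoxyphenyl is the first change at this place that only rearranges the same atoms, and it gives an at least 1.2-fold higher number from compound 3 to compound 4 (0.08 log units; that floor lies within the scatter). This is only a floor within the scatter, so the data do not show whether the rearrangement matters at this place or how large its effect is. With compound 4 now joining compound 1 and compound 2, the steps linking compound 4 to those two cannot be read, and the set has one actual number: the limit of > 20000 nM in this assay, at which 3 of the 4 values shown sit.

A group that gives a readable value well inside the measured range is still needed to size any effect at this place. Going by these compounds, whether an amine or a carboxylic acid on a double-bonded chain carbon bound to a double-bonded ring carbon would provide one remains open.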